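The compounds below may be only part of what the source reports. "The series", "measured", "known", "first", "only" and "open" are said of these compounds alone.

Three members of one series have been run in a functional assay on the whole organism (strain Wistar) for inhibition, with Rattus norvegicus as the target, read by paw edema, with stated times of 30 min and 120 min, at a dose of 50 mg/kg by the oral route; a higher number here means more inhibition at the dose given (going by the name of the read-out), a lower number less inhibition. Compound 1 `O=CN1N=C(c2ccc(F)cc2)CC1c1cn(-c2ccccc2)nc1-c1ccc(Cl)c(Cl)c1` gives 60.9% in this assay. Compound 2 `O=CN1N=C(c2ccc(Cl)cc2)CC1c1cn(-c2ccccc2)nc1-c1ccc(Cl)c(Cl)c1`, in which the change is chloro in place of fluoro on an aromatic carbon, gives 57.8% in this assay, a step of a number 3.1 percentage points lower from compound 1 to compound 2 (within the scatter). Compound 3 `CC(=O)N1N=C(c2ccc(F)cc2)CC1c1cn(-c2ccccc2)nc1-c1ccc(Cl)c(Cl)c1` gives 72.7% in this assay; its core differs from that of compound 1 by methyl in place of hydrogen on a carbonyl carbon, the step being a number 11.8 percentage points higher from compound 1 to compound 3 (beyond the scatter).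

Compound 4 `CC(=O)N1N=C(c2ccc(Cl)cc2)CC1c1cn(-c2ccccc2)nc1-c1ccc(Cl)c(Cl)c1` has not yet been measured. It differs from compound 3 by chloro in place of fluoro on an aromatic carbon, the same change as that between compound 1 and compound 2, at a place described in the same words. On the strength of the earlier step of a number 3.1 percentage points lower from compound 1 to compound 2 (within the scatter), a comparable small step a number 2.7 percentage points lower from compound 3 to compound 4 (within the scatter) is expected here. Compound 4 is accordingly estimated at 70% in this assay, with a likely range from 58% to 80%.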

Compound 4, a percentage reported as inhibition, in the whole organism at one dose (the size of the read-out at that dose, not a potency): 66.4%
Compound 4: middle estimate off by 3.6 percentage points, on the high side; measured number inside the range.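

In this assay, the change from 4-fluorophenyl to 4-chlorophenyl gives a step of a number 6.3 percentage points lower from compound 3 to compound 4 (within the scatter), and it reads alike on the two cores: the same change on two cores in this assay, a number 3.1 percentage points lower (within the scatter) from compound 1 to compound 2 and a number 6.3 percentage points lower (within the scatter) from compound 3 to compound 4, 3.2 percentage points apart, within the scatter of two such steps

Methyl in place of hydrogen on the carbonyl carbon gives a step of a number 8.6 percentage points higher from compound 2 to compound 4 (within the scatter), and this change also carries across: the same change on two cores in this assay, a number 11.8 percentage points higher (beyond the scatter) from compound 1 to compound 3 and a number 8.6 percentage points higher (within the scatter) from compound 2 to compound 4, 3.2 percentage points apart, within the scatter of two such steps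

This shows that both changes behaved alike on the two cores available, but two cores establish no rule for the series, and the halogen steps, lying within the scatter, do not show that the halogen exchange has any effect at all.

The compounds shown leave open how a methoxy group or a nitrile in place of the chloro would behave. They also leave open whether a longer chain in place of the methyl on the carbonyl carbon would follow the same steps.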